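Methyl on the aromatic nitrogen of compound 2

The source may hold more compounds than are shown below. What is called first, only, known or untested is meant among the compounds shown, and "the series" means these compounds.

In a functional assay on HeLa cells (Homo sapiens) for inhibition (a lower number here means a stronger inhibitor, a higher number a weaker inhibitor), compound 2 (`COc1cc(/C=C/c2c[nH]c3ccccc23)cc(OC)c1OC`) gives 3230 nM and stands level with compound 3 (`COc1cc(/C=C\c2c[nH]c3ccccc23)cc(OC)c1OC`) at 3230 nM on the digits shown. Compound 1 (`COc1cc(/C=C/c2cn(C(C)=O)c3ccccc23)cc(OC)c1OC`) gives > 5000 nM as a limit of the assay. Compound 4 (`COc1cc(/C=C/c2cn(C)c3ccccc23)cc(OC)c1OC`), not yet measured, carries methyl in place of hydrogen on an aromatic nitrogen. The nearest measured change, hydrogen in place of acetyl on that nitrogen, is an at least 1.5-fold lower number from compound 1 to compound 2 (0.18 log units; that floor lies within the scatter) and gives only a floor. The double-bond change is no change at the digits printed from compound 2 to compound 3 (within the scatter) and does not touch that nitrogen. Neither step shows a shift beyond the scatter, so the expected move is small, a 1.1-fold lower number from compound 2 to compound 4 (0.03 log units; within the scatter) as estimated, with no firm direction in this assay for now. For compound 4 the estimate is 3000 nM with an expected range from 1000 nM to 7000 nM for the coming measurement.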

Compound 4, half-maximal inhibitory concentration: 3090 nM
Estimate against measurement, compound 4: 1.0-fold (0.01 log units) below; measured number inside the range.
By their numbers in this assay, from the lowest: compounds 4, 2 and 3 (each within the scatter of the next). At a limit, above all of these: compound 1.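

In this assay, within the data shown here, methyl in place of hydrogen on the aromatic nitrogen gives a 1.0-fold lower number from compound 2 to compound 4 (0.02 log units; within the scatter), the first step at this position read between two numbers rather than against a limit. Compound 1 gives > 5000 nM, which is a limit of the assay. Methyl in place of acetyl therefore reads only as a floor, an at least 1.6-fold lower number from compound 1 to compound 4 (0.20 log units; that floor lies within the scatter).

Still open, going by these compounds, is whether a longer chain, or a chain ending in an amine or a carboxylic acid, on that nitrogen gives a step beyond the scatter. On these data alone, how far acetyl really stands from hydrogen or methyl also stays open.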